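A Chloro Substituent on the Core of Compound 1

A few compounds are considered here, and "the series" means these few. Any claim that something is new, unique, unknown or untested is made for them only; others in the source may bear on it.

Compound 1 `OCc1cc2ccccc2nc1-c1ccccc1O` gives the highest number of the three measured compounds in a functional assay on K562 cells (Homo sapiens) for cytotoxicity, read by MTT assay, with a stated time of 24 h; on this read-out lower numbers stand for stronger inhibition and higher numbers for weaker inhibition: compound 1 gives 74000 nM. Compound 2 `Cc1ccc2nc(-c3ccccc3O)c(CO)cc2c1` gives 12000 nM, and compound 3 `OCc1cc2cc(F)c(F)cc2nc1-c1ccccc1O` gives 12000 nM; both sit beyond the scatter under compound 1. For the measured compounds named here, the only step between compounds that differ in one place is a 6.2-fold lower number from compound 1 to compound 2 (0.79 log units; beyond the scatter). Compound 3 differs from compound 1 in two places, so only its two values can be set side by side, and they point the same way as that step.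

Compound 4 `OCc1cc2cc(Cl)ccc2nc1-c1ccccc1O` differs from compound 1 by chloro in place of hydrogen on an aromatic carbon. The step from compound 1 to compound 2 is the one that bears on it, since it also puts a single small group on an aromatic carbon of the shared core, and it was modest but beyond the scatter. A step of similar kind is therefore expected from compound 1 to compound 4, namely a 3.7-fold lower number from compound 1 to compound 4 (0.57 log units; beyond the scatter), with room for a smaller effect since the entering group is not the same. Compound 4 is estimated to give 20000 nM, within a range from 6000 nM to 60000 nM.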

Compound 4, half-maximal inhibitory concentration: 11000 nM
Compound 4: middle estimate off by 1.8-fold (0.26 log units), on the high side; low and high end bracket the measured number.
By their numbers in this assay, from the lowest: compounds 4, 2 and 3 (each within the scatter of the next); then compound 1.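

With chloro on this aromatic carbon, this assay shows a 6.7-fold lower number from compound 1 to compound 4 (0.83 log units; beyond the scatter), so a second group at this place gives a modest step beyond the scatter, as methyl did with a 6.2-fold lower number from compound 1 to compound 2 (0.79 log units; beyond the scatter). The change from methyl to chloro gives a 1.1-fold lower number from compound 2 to compound 4 (0.04 log units; within the scatter), which lies within the scatter, so the two groups cannot be told apart here. The earlier compounds shown here showed only that methyl could lower the number at this carbon; compound 4 shows that this is not confined to methyl. Nothing shown gives a measured account of what lies behind these steps. On these data alone, whether an amine, a methoxy group or a carboxylic acid on this carbon would give a number close to those of compound 2 and compound 4 remains open, and so does the outcome with a longer chain.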